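Oxopyrrolidinyl in place of difluorophenyl: cytotoxicity outlook

This account rests on a few compounds, and the source may have more. Where it says the series, first, only, none or still open, it means among the compounds named here.

In a toxicity assay on HepG2 2.2.15 cells (Homo sapiens) for cytotoxicity, read by CellTiter-Glo (a lower number here means that less compound is tolerated, a higher number that more compound is tolerated), compound 2 `O=C(Nc1cc(F)c(F)c(F)c1)N1Cc2c(-c3ccc(F)cc3F)cnn2CC1C1CC1` gives 32100 nM, the lowest of the two numbers measured in the series. Its nearest neighbour is compound 3 `O=C1CC(Oc2ncc(F)cn2)CN1c1cnn2c1CN(C(=O)Nc1cc(F)c(F)c(F)c1)C(C1CC1)C2`, which in this assay gives 96200 nM, a gap beyond the scatter. Compound 1 `O=C1CC(Oc2ncccn2)CN1c1cnn2c1CN(C(=O)Nc1cc(F)c(F)c(F)c1)C(C1CC1)C2` reaches only the limit of > 200000 nM in this assay. Going by the values given here, the one measured single-point step, an at least 2.0-fold lower number from compound 1 to compound 3 (0.31 log units; beyond the scatter), lies within the pair bearing the 2-oxopyrrolidin-1-yl group and does not touch the exchange now considered.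

Compound 4 `O=C1CC(c2ncco2)CN1c1cnn2c1CN(C(=O)Nc1cc(F)c(F)c(F)c1)C(C1CC1)C2` differs from compound 2 in that (4-(1,3-oxazol-2-yl)-2-oxopyrrolidin-1-yl in place of 2,4-difluorophenyl on an aromatic carbon). Among the compounds with values here, no measured step covers this exchange directly; it carries compound 4 into the 2-oxopyrrolidin-1-yl pattern of compounds 1 and 3, whose numbers both stand above that of compound 2. An upward step is therefore expected, estimated as a 3.4-fold higher number from compound 2 to compound 4 (0.53 log units; beyond the scatter), with a real chance that compound 4 reports only a limit. Compound 4 is expected at 110000 nM, within 35000 nM to 200000 nM.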

Compound 4, half-maximal cytotoxic concentration: > 200000 nM
Compound 4 gave a limit, no number; the forecaster's own chance of this, stated with the estimate: 35%; at least 1.8-fold (0.25 log units) between middle value and limit.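

In this assay, the exchange on this aromatic carbon now has a measured size, with 4-(1,3-oxazol-2-yl)-2-oxopyrrolidin-1-yl in place of 2,4-difluorophenyl: an at least 6.2-fold higher number from compound 2 to compound 4 (0.79 log units; beyond the scatter). The group on the saturated ring carbon of the 2-oxopyrrolidin-1-yl pattern also shifts the read-out, since 1,3-oxazol-2-yl in place of (5-fluoropyrimidin-2-yl)oxy gives an at least 2.0-fold higher number from compound 3 to compound 4 (0.31 log units; beyond the scatter). The step between compound 1 and compound 4 joins two limits and cannot be read: the limit of > 200000 nM in this assay, at which 2 of the 4 values shown sit.

From the compounds shown here alone, how far compound 1 and compound 4 stand from each other therefore stays open. Also open, going by these compounds, is how an amine or a carboxylic acid on that saturated ring carbon would read in this assay, and whether either would come in under the limit.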